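A Longer Chain on an Inactive Series

A few compounds are considered here, and "the series" means these few. Any claim that something is new, unique, unknown or untested is made for them only; others in the source may bear on it.

Compound 1 `CCCCCCC(CCO)n1cnc2c(OC)ncnc21` is where this step starts. In a functional assay on SW480 cells (Homo sapiens) for antiproliferative activity, read by MTT assay, with a stated time of 48 h (on this read-out higher numbers stand for weaker inhibition and lower numbers for stronger inhibition), compound 1 gives > 50000 nM, which is a limit and not a number. Compound 2 `CCCCCCC(CCO)n1cnc2c(NC)ncnc21` gives > 50000 nM, again a limit. Compound 3 `CCCCCCC(CCO)n1cnc2c(N(C)C)ncnc21` gives > 50000 nM, also a limit. Within the data shown here, the whole record so far is the limit of > 50000 nM in this assay, at which 3 of the 3 values shown sit, so no compound can be ranked against another.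

Compound 4 `CCCCCCCCC(CCO)n1cnc2c(OC)ncnc21` keeps the shared core and lengthens the chain: ethyl in place of hydrogen on a saturated chain carbon, seven bonds along the chain from an aromatic nitrogen. In words, ethyl stands in place of hydrogen on a saturated chain carbon, and the same difference can be read as propyl to pentyl.

Three measured steps exist: a step that the two limits leave unreadable from compound 1 to compound 2, a step that the two limits leave unreadable from compound 1 to compound 3 and a step that the two limits leave unreadable from compound 2 to compound 3. They swap methoxy for methylamino or dimethylamino, or add a methyl on a nitrogen, and none of them alters the chain. They therefore give no size to carry over, and any forecast is loose.

A small move toward stronger inhibition is expected, though this assay may well report only a limit again. The expected change is an at least 1.4-fold lower number from compound 1 to compound 4 (0.15 log units; that floor lies within the scatter). Compound 4 is estimated at 35000 nM, with an expected range of 10000 nM to 80000 nM.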

Compound 4, half-maximal inhibitory concentration: 24600 nM
Compound 4: middle estimate off by 1.4-fold (0.15 log units), on the high side; the range from low to high includes it.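

Among these compounds, compound 4 is the first compound here to give a number and not a limit in this assay, so the chain change, read as propyl to pentyl, is the first change with a readable direction. Among the compounds shown here, that change gives an at least 2.0-fold lower number from compound 1 to compound 4 (0.30 log units; that floor lies within the scatter) and this figure is a floor, not a measured size, while the earlier steps among compound 1, compound 2 and compound 3 cannot be read at all. Only this floor can be stated, and nothing can be said about the earlier swaps on the aromatic carbon or the added methyl on a nitrogen, because the record is held almost entirely at one limit: the limit of > 50000 nM in this assay, at which 3 of the 4 values shown sit.

As far as these compounds go, one chain step cannot show a trend, so whether a still longer chain, such as octyl or decyl, would carry the number further down remains open. Also open, from the compounds shown here alone, is whether the methylamino group of compound 2 or the dimethylamino group of compound 3 would give a number when paired with the chain of compound 4.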